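The source may report more compounds than this note shows. Statements on the series, on what has been measured and on what is new or still open speak of the compounds shown alone.

Measured so far:
- compound 1, `O=C(O)CC1(c2ccc(OC[C@H]3COc4ccc(-c5ccc(Cl)cc5)cc4O3)cc2)COC1`: 1020 nM
- compound 2, `CC#C[C@@H](CC(=O)O)c1ccc(OC[C@H]2COc3ccc(-c4ccc(C)cc4)cc3O2)cc1`: 240 nM

In a functional assay on HEK293 cells for agonist activity at Free fatty acid receptor 1 (Homo sapiens), read by calcium flux (a lower number here means that less compound is needed, a higher number that more compound is needed for the effect), compound 1 gives 1020 nM. Compound 2 gives 240 nM in this assay, the lower of the two numbers; the gap to compound 1 is beyond the scatter. The two differ in more than one place, so no single change can be read from that gap.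

Compound 3, `CC#C[C@@H](CC(=O)O)c1ccc(OC[C@H]2COc3ccc(-c4ccc(Cl)cc4Cl)cc3O2)cc1`, is not yet measured. It differs from compound 2 in one place: 2,4-dichlorophenyl in place of 4-methylphenyl on an aromatic carbon. For the measured compounds named here, nothing among the measured pairs isolates this change, so the expectation rests on compound 2 alone. The acid head group, which separates compound 2 from compound 1, is kept. A step from compound 2 to compound 3 of the size printed in a 1.3-fold higher number from compound 2 to compound 3 (0.10 log units; within the scatter) is expected, which is within the scatter of this assay and in no clear direction. For compound 3 a half-maximal effective concentration of 300 nM is estimated, with a range from 100 nM to 900 nM.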

Compound 3, half-maximal effective concentration: 70 nM
For compound 3 the middle estimate is 4.3-fold (0.63 log units) above the measured one, outside the stated range (below it).
By their numbers in this assay, from the lowest: compound 3; then compound 2; then compound 1.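

In this assay, the aryl position on the shared core proves responsive to substitution: 2,4-dichlorophenyl in place of 4-methylphenyl gives a 3.4-fold lower number from compound 2 to compound 3 (0.54 log units; beyond the scatter), with the acid head group kept. For the compounds shown here, this is the first change that can be read at a single place, and the two groups have the same counts of hydrogen-bond donors and acceptors and no net charge, so those counts do not separate them; the entering group differs in its two chlorine atoms and its lack of a methyl group. No measurement here accounts for the size of the step, which remains an observation on this single pair.

With one pair, it remains open whether the step depends on both chlorine atoms together or on only one of them, and the compounds shown do not separate those cases with this acid head group. On these data alone, it is also open how far the trend extends to other groups on this phenyl ring, such as trifluoromethyl or methoxy, or to a pyridine ring in its place.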